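The source may report more compounds than this note shows. Statements on the series, on what has been measured and on what is new or still open speak of the compounds shown alone.

Among the compounds with values here, compound 1 (`O=C(Nc1ccc(NCC2CCCC2)cc1Cl)c1cc(Cl)ccc1O`) gives 21500 nM in an ADME assay on A549 cells (Homo sapiens) for cytotoxicity, read by resazurin assay, with a stated time of 48 h (a higher number here means that more compound is tolerated, a lower number that less compound is tolerated), and compound 2 (`CCN(CC)c1ccc(NC(=O)c2cc(Cl)ccc2O)c(Cl)c1`) gives 55500 nM there, the higher of only two numbers so far, so these cells tolerate more of compound 2. Compound 3 (`O=C(Nc1ccc(NCc2ccc(F)cc2)cc1Cl)c1cc(Cl)ccc1O`) keeps the shared core but carries (4-fluorobenzyl)amino in place of diethylamino on an aromatic carbon. Within the data shown here, the one measured step that bears on this swap also involves diethylamino (a 2.6-fold higher number from compound 1 to compound 2 (0.41 log units; beyond the scatter)), and it is modest in size yet beyond the scatter. Read in reverse, leaving diethylamino in compound 2 for (cyclopentylmethyl)amino in compound 1 goes with the lower 21500 nM in that pair, so a modest fall is expected here too. A single step is thin support, and the entering group is not the same one. The expected change is a 2.8-fold lower number from compound 2 to compound 3 (0.44 log units; beyond the scatter) in this estimate. Compound 3 is estimated at 20000 nM within an expected range of 8000 nM to 50000 nM on this read-out.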

Compound 3, half-maximal cytotoxic concentration: 54400 nM
Estimate against measurement, compound 3: 2.7-fold (0.43 log units) below, and the stated range ends below it.
By their numbers in this assay, from the lowest: compound 1; then compounds 3 and 2 (each within the scatter of the next).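

In this assay, (4-fluorobenzyl)amino in place of diethylamino gives a 1.0-fold lower number from compound 2 to compound 3 (0.01 log units; within the scatter), so at this position, para to a large group, two groups that differ in heavy atoms, in the presence of a six-membered aromatic ring and in hydrogen-bond donors give numbers that cannot be told apart. The second step, 4-fluorophenyl in place of cyclopentyl on the saturated chain carbon, gives a 2.5-fold higher number from compound 1 to compound 3 (0.40 log units; beyond the scatter), which shows that a ring at the end of this short amino substituent does not by itself go with the lower number: among these three compounds, the ring-bearing substituents of compound 1 and compound 3 fall on opposite sides of the scatter. Nothing measured here accounts for the difference between these two rings.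

The compounds shown leave open what a plain benzylamino group without the fluorine would give, and so whether the fluorine has any part in the step from cyclopentyl to 4-fluorophenyl. They also leave open whether a simple unsubstituted amino group or (cyclohexylmethyl)amino at this position would fall with compound 1 or with compound 2 and compound 3.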